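Aminothiophene ketone series: aryl swap on the piperazine nitrogen

A few compounds are considered here, and "the series" means these few. Any claim that something is new, unique, unknown or untested is made for them only; others in the source may bear on it.

Compound 1 `Nc1scc(CN2CCN(c3ccc(OC(F)(F)F)cc3)CC2)c1C(=O)c1ccc(Cl)cc1` gives -51% in a functional assay on CHO cells with adenosine receptor A1 (Homo sapiens) as the target, read by cAMP accumulation and immunoassay, with a stated time of 6 min, tested at 1 uM; a lower number here means a stronger effect, a higher number a weaker effect of the compound at the concentration tested. Compound 3 `Nc1scc(CN2CCN(c3cccc(F)c3)CC2)c1C(=O)c1cccc(C(F)(F)F)c1` gives -35% and compound 2 `Nc1scc(CN2CCC(c3ccc(Cl)cc3)CC2)c1C(=O)c1ccc(Cl)cc1` gives -24%, both higher by more than the scatter, so compound 1 stands lowest of the three, with compound 3 nearer to it than compound 2. Among the measured compounds shown here, no pair of measured compounds differs in one place only, so no single-change step is available. Compound 4 `Nc1scc(CN2CCN(c3c(F)cccc3F)CC2)c1C(=O)c1ccc(Cl)cc1` is not yet measured and differs from compound 1 by 2,6-difluorophenyl in place of 4-(trifluoromethoxy)phenyl on an amine nitrogen in a ring. Compound 3 and compound 2 each differ from compound 1 in more than one place, so neither isolates this change. A modest rise in the number, that is a weaker effect, is expected, with the estimated step being a number 13 percentage points higher from compound 1 to compound 4 (beyond the scatter). Compound 4 is expected to give -38%, with a range of -60% to -15%.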

Compound 4, a percentage reported as activity, at one concentration (the size of the read-out at that concentration, not a potency): -65%
Estimate against measurement, compound 4: 27 percentage points above, and the stated range ends above it.
By their numbers in this assay, from the lowest: compound 4; then compound 1; then compound 3; then compound 2.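

In this assay, among the compounds shown here, 2,6-difluorophenyl in place of 4-(trifluoromethoxy)phenyl on an amine nitrogen in a ring gives a number 14 percentage points lower from compound 1 to compound 4 (beyond the scatter), the first single-change reading. The entering group has fewer heavy atoms and no hydrogen-bond acceptor, so neither the larger aryl group nor that acceptor is needed for a number this low. No measurement available here explains the step.

The fluorine pattern and the loss of the trifluoromethoxy group change together, so their contributions remain unseparated. An unsubstituted phenyl or a pyridine ring on this nitrogen would help to separate them.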